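Replacing the group on the carbonyl of compound 1

The source may report more compounds than this note shows. Statements on the series, on what has been measured and on what is new or still open speak of the compounds shown alone.

Measured so far in a functional assay on NCI-H1581 cells (Homo sapiens) for antiproliferative activity, read by CCK-8 assay, with a stated time of 72 h; on this read-out higher numbers stand for weaker inhibition and lower numbers for stronger inhibition
- compound 1 `COc1cc(OC)c(Cl)c(-c2ccc3c(NC(=O)c4ccc(N5CCCCC5)cc4)n[nH]c3n2)c1Cl` gives 558 nM
- compound 2 `COc1cc(OC)c(Cl)c(-c2ccc3c(NC(=O)c4ccc(N5CCN(C6CCC6)CC5)cc4)n[nH]c3n2)c1Cl` gives 2.3 nM
- compound 3 `C=CCN1CCN(c2ccc(C(=O)Nc3n[nH]c4nc(-c5c(Cl)c(OC)cc(OC)c5Cl)ccc34)cc2)CC1` gives 3.3 nM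

Compound 1 has the highest number of the three and is the weakest here, with both steps away from it beyond the scatter. Compound 4 (`COc1cc(OC)c(Cl)c(-c2ccc3c(NC(=O)c4ccc(N5CCN(C)CC5)s4)n[nH]c3n2)c1Cl`) has not been measured yet. It keeps the shared core, and its change from compound 1 is this (a group of 12 heavy atoms (9 carbon, 2 nitrogen, 1 sulfur; one five-membered aromatic ring with 1 hetero atom, one six-membered non-aromatic ring with 2 hetero atoms) in place of a group of 12 heavy atoms (11 carbon, 1 nitrogen; one six-membered non-aromatic ring with 1 hetero atom, one six-membered aromatic ring of carbon only), on a carbonyl carbon). Among the compounds with values here, two measured steps bear on it (a 240-fold lower number from compound 1 to compound 2 (2.38 log units; beyond the scatter); a 170-fold lower number from compound 1 to compound 3 (2.23 log units; beyond the scatter)). Both are large, and each puts a six-membered non-aromatic ring with 2 hetero atoms in place of piperidin-1-yl, as compound 4 also does. A third step (a 1.4-fold higher number from compound 2 to compound 3 (0.16 log units; within the scatter)) lies within the scatter. Within the data shown here, no measured step tests a five-membered aromatic ring with 1 hetero atom in place of the six-membered aromatic ring of carbon only, so the expectation stays loose. A large move towards lower numbers is expected, though perhaps a somewhat smaller one (a 47-fold lower number from compound 1 to compound 4 (1.67 log units; beyond the scatter)). Compound 4 is estimated at 12 nM in this assay with an expected range (2 nM to 80 nM).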

Compound 4, half-maximal inhibitory concentration: 3.7 nM
For compound 4 the middle estimate is 3.2-fold (0.51 log units) above the measured one; low and high end bracket the measured number.
By their numbers in this assay, from the lowest: compounds 2, 3 and 4 (each within the scatter of the next); then compound 1.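

In this assay, the group on the carbonyl carbon can change its aromatic ring as well as its non-aromatic ring and still give a large move to stronger inhibition, a 150-fold lower number from compound 1 to compound 4 (2.18 log units; beyond the scatter). Within the data shown here, until now, that kind of move had been seen only with the six-membered aromatic ring of carbon only; here it also appears with a five-membered aromatic ring holding sulfur. Compound 4 falls within the scatter of compounds 2 and 3, so this ring swap, made with a small methyl group on the amine, leaves it among the three lowest numbers. No measured property is available to explain the change.

Both rings differ at once between compound 1 and compound 4, so their separate contributions cannot be told apart. Going by these compounds, it also remains open how a furan ring in place of the sulfur ring, or a morpholine ring in place of the ring with two nitrogens, would behave.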